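The source may hold more compounds than are shown below. What is called first, only, known or untested is meant among the compounds shown, and "the series" means these compounds.

Three compounds built on the shared core were tested in an ADME assay on HepG2 cells (Homo sapiens) for cytotoxicity, read by CellTiter-Glo and ATP content, with a stated time of 72 h; a higher number here means that more compound is needed for the effect, a lower number that less compound is needed. Compound 1 `Cc1ccc(N2CCN(C(=O)C3CCN(C(=O)c4ccc(S(C)(=O)=O)c([N+](=O)[O-])c4)CC3)CC2)cc1` reaches only the limit of the assay, giving > 27000 nM. Compound 2 `CC(C)N(C(=O)CNC(=O)c1ccc(S(C)(=O)=O)c([N+](=O)[O-])c1)C(C)C` likewise stops at the limit, with > 27000 nM. Compound 3 `Cc1ccc(N2CCN(C(=O)CCCNC(=O)c3ccc(S(C)(=O)=O)c([N+](=O)[O-])c3)CC2)cc1` also returns a limit, reported as > 27000 nM. Compound 2 therefore stands nowhere distinct among the three: every value sits at the limit of > 27000 nM in this assay, at which 3 of the 3 values shown sit, and no number separates one compound from another. Going by the values given here, no step between measured compounds can be drawn from these results, since none of them is a number.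

Compound 4 `CN1CCN(C(=O)CNC(=O)c2ccc(S(C)(=O)=O)c([N+](=O)[O-])c2)CC1` has not yet been measured in this assay. It differs from compound 2 in one place: 4-methylpiperazin-1-yl in place of diisopropylamino on a carbonyl carbon. Among the compounds with values here, every measured value is a limit, so the data give no step to lean on. The change itself carries no measured property in this set. The step that the limit leaves unreadable from compound 2 to compound 4 is expected to be none beyond the scatter, in neither direction, with the read-out most probably reported again as a limit rather than a number. Compound 4 is accordingly estimated at 30000 nM, within a range from 15000 nM to 60000 nM.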

Compound 4, half-maximal effective concentration: > 27000 nM
Compound 4 was reported as a limit; the forecaster's own chance of this, stated with the estimate: 85%; the middle value is on the limit's open side.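

In this assay compound 4 returns > 27000 nM as a limit of the assay and not a number. Going by these compounds alone, compound 2 also stands at a limit, so no step from compound 2 to compound 4 can be read. The compounds shown leave open at what concentration any of them would reach the half-maximal effect, since every value stands at: the limit of > 27000 nM in this assay, at which 4 of the 4 values shown sit.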